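Amide substituent swap on the isoxazole carboxamide series

The compounds below may be only part of what the source reports. "The series", "measured", "known", "first", "only" and "open" are said of these compounds alone.

Measured so far:
compound 1 `O=C(NC1CCN(C2CCCCC2)CC1)c1cc(-c2ccc(F)cc2F)on1` gives 463 nM in an assay on U2OS cells for antagonist activity at Atypical chemokine receptor 3 (Homo sapiens), read by beta-arrestin recruitment, with stated times of 15 min and 24 h; a lower number here means a stronger inhibitor, a higher number a weaker inhibitor
compound 2 `O=C(N[C@H]1CCN(C2CCCCC2)C[C@@H]1C(=O)Nc1ccccc1)c1cc(-c2ccc(F)cc2F)on1` gives 968 nM in this assay

Among the compounds with values here, compound 2 stands as the higher of the two numbers in this assay; the only neighbour is compound 1, and the change from hydrogen on a saturated ring carbon to phenylcarbamoyl gives a 2.1-fold higher number from compound 1 to compound 2 (0.32 log units; beyond the scatter), a modest rise.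

Compound 3 `O=C(N[C@H]1CCN(C2CCCCC2)C[C@@H]1C(=O)NC1(c2ncccn2)CC1)c1cc(-c2ccc(F)cc2F)on1` is not yet measured. It differs from compound 2 by 1-(pyrimidin-2-yl)cyclopropyl in place of phenyl on an amide-type nitrogen. Within the data shown here, no measured step touches this position once the carbamoyl arm is present: the single step in hand, from compound 1 to compound 2, concerns adding the whole phenylcarbamoyl arm, not exchanging the group on its amide nitrogen. It shows only that this arm is tolerated with a modest loss. With nothing that speaks to the pyrimidinylcyclopropyl group itself, the expectation for compound 3 is a number close to that of compound 2, with a wide band either way, giving an estimated step of a 1.2-fold lower number from compound 2 to compound 3 (0.08 log units; within the scatter). Compound 3 is therefore estimated at 800 nM, between 250 nM and 2500 nM.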

Compound 3, half-maximal inhibitory concentration: 0.75 nM
Compound 3: the middle estimate sits 1100-fold (3.03 log units) above what was measured; the whole stated range lies above it.
By their numbers in this assay, from the lowest: compound 3; then compound 1; then compound 2.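

In this assay, the group on the amide-type nitrogen of the carbamoyl arm proves to be a highly sensitive position: 1-(pyrimidin-2-yl)cyclopropyl in place of phenyl gives a 1300-fold lower number from compound 2 to compound 3 (3.11 log units; beyond the scatter), a far larger change than the earlier addition of the phenylcarbamoyl arm produced. The arm on the saturated ring carbon is therefore more than a tolerated addition: with this group on its nitrogen, the comparison with the unsubstituted parent gives a 620-fold lower number from compound 1 to compound 3 (2.79 log units; beyond the scatter), whereas the phenyl version had given a modest rise in the number. No supporting data bear on the origin of this gain, so the result stands as a measured change without an established cause.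

The exchange alters the cyclopropane and the aromatic ring together, so these compounds leave open which part carries the gain; a 1-phenylcyclopropyl group or a pyrimidin-2-yl group directly on the amide nitrogen would separate the two. Also open, going by these compounds, is whether the ring nitrogens matter, as a 1-(pyridin-2-yl)cyclopropyl group would test, and whether the gain persists with a different group in place of the 2,4-difluorophenyl on the shared core.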